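Fluoro to chloro exchange: from compound 1 to compound 4

This account rests on a few compounds, and the source may have more. Where it says the series, first, only, none or still open, it means among the compounds named here.

Three compounds carry numbers in a functional assay on HEK293 cells for agonist activity at D(4) dopamine receptor (Homo sapiens), read by FLIPR; on this read-out lower numbers stand for an effect already at smaller amounts and higher numbers for an effect only at larger amounts of compound. Compound 1 `O=C(CN1CCC(c2cccc[n+]2[O-])CC1)Nc1cccc(F)c1` gives 160 nM and stands second highest of the three. Compound 2 `c1ccc(C2CCN(Cc3nc4ccccc4[nH]3)CC2)nc1` gives 12 nM, a much lower number. Compound 3 `N#Cc1cccc(C(=O)NCN2CCC(c3cccc[n+]3[O-])CC2)c1` gives 840 nM, a higher number than compound 1. Among the measured compounds shown here, no step between these measured compounds is a single change, so the gaps only show where each one lies. Compound 4 `O=C(CN1CCC(c2cccc[n+]2[O-])CC1)Nc1cccc(Cl)c1` is not yet measured. It differs from compound 1 in one place: chloro in place of fluoro on an aromatic carbon, on an aromatic carbon meta to a large group. For the measured compounds named here, with no step of the same kind among the measured compounds, a small change is expected, in either direction or none beyond the scatter. For compound 4 the estimate in this assay is 120 nM, within 40 nM to 400 nM, so that the expected step of a 1.3-fold lower number from compound 1 to compound 4 (0.12 log units; within the scatter) stays near the scatter.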

Compound 4, half-maximal effective concentration: 62 nM
The estimate for compound 4 lay 1.9-fold (0.29 log units) above the measured number; measured number inside the range.
By their numbers in this assay, from the lowest: compound 2; then compound 4; then compound 1; then compound 3.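

In this assay, among the compounds shown here, chloro in place of fluoro on an aromatic carbon meta to a large group gives a 2.6-fold lower number from compound 1 to compound 4 (0.41 log units; beyond the scatter) and is the first single-place change. For the compounds shown here, this position therefore registers a modest response to one halogen replacing another, which the earlier compounds, none a single change from another, could not show. No measurement at hand accounts for the step. On these data alone, whether bromo, methyl or methoxy at this place would extend the step stays open, as does the outcome with the substituent removed altogether.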